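A Ring-Bearing Group Gives Way to a Smaller One

The source may report more compounds than this note shows. Statements on the series, on what has been measured and on what is new or still open speak of the compounds shown alone.

In a functional assay with Oryctolagus cuniculus as the target (a lower number here means a stronger inhibitor, a higher number a weaker inhibitor), compound 1 (`CC/N=C(/N)Nc1nc(-c2ccc(OC)cc2)c(-c2ccc(OC)cc2)s1`) gives > 100 nM, which is a limit and not a number. Compound 2 (`COc1ccc(-c2nc(/N=C(\N)NC3CCCCC3)sc2-c2ccc(OC)cc2)cc1`) gives > 1000 nM, which is also a limit, so it has no exact position on the scale. Among the compounds with values here, the one measured step is a step that the two limits leave unreadable from compound 1 to compound 2. Compound 3 (`C/N=C(/NC)Nc1nc(-c2ccc(OC)cc2)c(-c2ccc(OC)cc2)s1`) differs from compound 2 as follows: a group of 6 heavy atoms (3 carbon, 3 nitrogen; no ring) in place of a group of 10 heavy atoms (7 carbon, 3 nitrogen; one six-membered non-aromatic ring of carbon only), on an aromatic carbon. This reverses the change in group size seen in the measured step, but that step offers no size to carry over. The expectation therefore rests loosely on compound 1, which carries a group of the same counts and has a limit of > 100 nM. A move toward stronger inhibition is expected, with the estimated step being an at least 2.5-fold lower number from compound 2 to compound 3 (0.39 log units; beyond the scatter). For compound 3 the estimated value is 400 nM, with an expected range of 80 nM to 3000 nM.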

Compound 3, half-maximal inhibitory concentration: 970 nM
The estimate for compound 3 lay 2.4-fold (0.38 log units) below the measured number, and the stated range covers the measured number.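

Compound 3 gives the series its first exact number at this aromatic carbon of the five-membered ring: in this assay compound 3 gives 970 nM. Replacing the group bearing the six-membered carbon ring with the smaller group without a ring amounts to an at least 1.0-fold lower number from compound 2 to compound 3 (0.01 log units; that floor lies within the scatter), so the data show no gain beyond the scatter, though a larger one is not excluded. The reading for compound 2 is a limit and not a number, and the size of this step rests on it: the limit of > 1000 nM in this assay, at which 1 of the 3 values shown sits.

The steps from compound 1 to compound 2 and to compound 3 cannot be read, which leaves open how the groups on the nitrogen compare. Also open, going by these compounds, is how a simple amine or a longer chain at this aromatic carbon would read in this assay.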